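This account rests on a few compounds, and the source may have more. Where it says the series, first, only, none or still open, it means among the compounds named here.

Measured in an ADME assay on MT4 cells (Homo sapiens) for cytotoxicity, read by MTT assay; a higher number here means that more compound is tolerated, a lower number that less compound is tolerated:
- compound 1 `Cc1ccccc1C(=O)N(C(=S)OCCN1C(=O)c2ccccc2C1=O)c1ccc(Cl)cc1`: 21000 nM
- compound 2 `O=C1c2ccccc2C(=O)N1CCOC(=S)N(C(=O)c1ccc(F)cc1F)c1ccc(Cl)cc1`: 52000 nM
- compound 3 `O=C1c2ccccc2C(=O)N1CCOC(=S)N(C(=O)c1c(F)cccc1F)c1ccc(Cl)cc1`: 39000 nM

Compound 3 stands within the scatter of the other two measured compounds. The steps to it are a 1.9-fold higher number from compound 1 to compound 3 (0.27 log units; within the scatter) and a 1.3-fold lower number from compound 2 to compound 3 (0.12 log units; within the scatter).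

Compound 4 `O=C1c2ccccc2C(=O)N1CCOC(=S)N(C(=O)c1cccc(Cl)c1Cl)c1ccc(Cl)cc1` is still unmeasured. Its difference is 2,3-dichlorophenyl in place of 2,6-difluorophenyl on a carbonyl carbon, with 2,3-dichlorophenyl in place of 2,6-difluorophenyl on a carbonyl carbon.

All three measured steps are swaps at this carbonyl carbon. The largest is modest, a 2.5-fold higher number from compound 1 to compound 2 (0.39 log units; beyond the scatter), and no chlorinated group has been measured there. No shift beyond the scatter is therefore expected in this assay, only a slight drift at most, with an estimated 1.3-fold lower number from compound 3 to compound 4 (0.11 log units; within the scatter).

Compound 4 is expected at 30000 nM, with an estimated range of 13000 nM to 70000 nM.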

Compound 4, half-maximal cytotoxic concentration: 54000 nM
Compound 4: middle estimate off by 1.8-fold (0.26 log units), on the low side; measured number inside the range.
By their numbers in this assay, from the lowest: compounds 1, 3, 2 and 4 (each within the scatter of the next, the first and the last beyond it).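

In this assay, going by these compounds alone, 2,3-dichlorophenyl, the first chlorinated group on this carbonyl carbon, falls within the scatter of both difluorophenyl compounds (a 1.4-fold higher number from compound 3 to compound 4 (0.14 log units; within the scatter); a 1.0-fold higher number from compound 2 to compound 4 (0.02 log units; within the scatter)). Against 2-methylphenyl, the change lies beyond the scatter (a 2.6-fold higher number from compound 1 to compound 4 (0.41 log units; beyond the scatter)), although compound 3 goes against any general separation of halogenated groups from compound 1. No available evidence bears on the reason for these steps.

As far as these compounds go, whether this tolerance extends beyond substituted phenyl groups remains open. An aminophenyl or carboxyphenyl group, or a longer alkyl chain, on this carbonyl carbon could test that.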